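The source may report more compounds than this note shows. Statements on the series, on what has been measured and on what is new or still open speak of the compounds shown alone.

Measured so far in this series:

compound 1, `CC(C)CC1(CCCCN2CCN(c3cccc(Cl)c3)CC2)C(=O)Nc2ccccc21`: 1.8 nM
compound 2, `CCC1(CCCCN2CCN(c3ccc(OC)cc3)CC2)C(=O)Nc2ccccc21`: 25.4 nM
compound 3, `CCC1(CCCCN2CCN(c3cccc(Cl)c3)CC2)C(=O)Nc2ccc(Cl)cc21`: 8.27 nM

In an assay on CHO cells for displacement of a labelled ligand from 5-hydroxytryptamine receptor 7 (Homo sapiens) (on this read-out higher numbers stand for weaker inhibition and lower numbers for stronger inhibition), compound 2 stands at the highest of the three numbers, so it is the weakest of the measured compounds. Its nearest neighbour is compound 3, whose number is lower by more than the usual scatter; compound 1 lies further off still, with the lowest number of the set. Both compounds 1 and 3 carry a 3-chlorophenyl on the ring amine nitrogen, whereas compound 2 carries a 4-methoxyphenyl there; they also differ from compound 2 elsewhere, so none of these pairs is a single-point step.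

The next compound is compound 4, `CCC1(CCCCN2CCN(c3ccc(Cl)c(Cl)c3)CC2)C(=O)Nc2ccccc21`. Relative to compound 2 the change is 3,4-dichlorophenyl in place of 4-methoxyphenyl on an amine nitrogen in a ring. Among the measured compounds shown here, no measured pair differs in only this position, so the step has no direct precedent. Given that compound 3 gives 8.27 nM and compound 1 gives 1.8 nM in this assay with a chlorine-bearing phenyl on that nitrogen, the change is expected to lower the number, by a step beyond the scatter.

For compound 4 in this assay the expected value is 6 nM, in the range 2 nM to 18 nM, which corresponds to an expected step of a 4.2-fold lower number from compound 2 to compound 4 (0.63 log units; beyond the scatter).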

Compound 4, inhibition constant: 0.63 nM
Compound 4: the middle estimate sits 9.5-fold (0.98 log units) above what was measured; measured number outside the range, below it.
By their numbers in this assay, from the lowest: compound 4; then compound 1; then compound 3; then compound 2.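

In this assay, 3,4-dichlorophenyl in place of 4-methoxyphenyl on the amine nitrogen in the ring gives a 40-fold lower number from compound 2 to compound 4 (1.61 log units; beyond the scatter) with the rest of the molecule unchanged. Among the compounds shown here, this is the first single-change reading, and it shows that this substituent position alone can carry a large step in the number. The two groups match in heavy-atom count and both hold one six-membered aromatic ring of carbon only, so those counts do not separate them, whereas the hydrogen-bond acceptor of the 4-methoxyphenyl group has no counterpart in the 3,4-dichlorophenyl group; no measurement shown here accounts for the step.

As far as these compounds go, the change removes the methoxy group and brings in two chlorines in a single step, so the contribution of each remains open, and a plain phenyl or a 4-chlorophenyl group on the same core would help to separate them. Also open, from the compounds shown here alone, is whether a step of this size carries over to cores with other substituents, such as the core of compound 1 or of compound 3.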